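A few compounds are considered here, and "the series" means these few. Any claim that something is new, unique, unknown or untested is made for them only; others in the source may bear on it.

Measured compounds in a functional assay on K562 cells (Homo sapiens) for antiproliferative activity, read by sulforhodamine B assay, with a stated time of 48 h, tested at 50 uM; a lower number here means less inhibition, a higher number more inhibition at the concentration tested (going by the name of the read-out):
compound 1 `CC1=CC[C@H](C(C)C)c2cc(C)c(OC(=O)c3ccc([N+](=O)[O-])cc3)cc21` gives 89%
compound 2 `CC1=CC[C@H](C(C)C)c2cc(C)c(OC(=O)c3ccccc3)cc21` gives "not active" (no number reported)
compound 3 `CC1=CC[C@H](C(C)C)c2cc(C)c(OC(=O)c3ccc(Cl)cc3)cc21` gives 58.9%

Compound 3 stands lowest of the two numbers reported in this assay; its nearest neighbour is compound 1, and the step of a number 30.1 percentage points lower from compound 1 to compound 3 (beyond the scatter) lies beyond the scatter, while compound 2 carries no number at all. Compound 4 `CC1=CC[C@H](C(C)C)c2cc(C)c(OC(=O)c3cccc(Cl)c3)cc21` is not yet measured. It differs from compound 3 by 3-chlorophenyl in place of 4-chlorophenyl on a carbonyl carbon: the 4-chlorophenyl leaves and a 3-chlorophenyl enters, with the same atoms joined differently. For the measured compounds named here, no measured step moves a chlorine within the ring; the only step known, from nitro to chloro, does not bear on this change. Compound 4 is therefore expected to stay close to compound 3, with a step of a number 3.9 percentage points lower from compound 3 to compound 4 (within the scatter) not beyond the scatter, and an estimated value of 55% (range 30% to 80%).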

Compound 4, a percentage reported as inhibition, at one concentration (the size of the read-out at that concentration, not a potency): "not active" (no number reported)
Compound 4 has no reported number here; no gap can be computed for the estimate.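

For the compounds shown here, compound 4 is reported as "not active" (no number reported), so no step from compound 3 to it can be read. Nothing shown accounts for this result. The compounds shown leave open how compound 2 and compound 4 compare in number with compound 3.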